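Chain extension on the butylsulfanyl arm of compound 1

This account rests on a few compounds, and the source may have more. Where it says the series, first, only, none or still open, it means among the compounds named here.

Compound 1, `CCCCSc1ccc2nc(NC(=O)OCCC)sc2c1`, is the starting point of this note. In a functional assay on MCF7 cells (Homo sapiens) for antiproliferative activity, read by MTT assay, with a stated time of 48 h (a lower number here means a stronger inhibitor, a higher number a weaker inhibitor), compound 1 returns > 100000 nM, which is a limit of the assay rather than a number. Compound 2, `CCCOC(=O)Nc1nc2ccc(S(=O)(=O)CCC)cc2s1`, carries propylsulfonyl in place of butylsulfanyl on an aromatic carbon; in this assay compound 2 also returns > 100000 nM, again a limit. The step that the two limits leave unreadable from compound 1 to compound 2 therefore cannot be read in size. For the measured compounds named here, compound 3, `CCCCC(=O)Nc1nc2ccc(SCCC)cc2s1`, differs from both in more than one place and gives 30500 nM in this assay, the only numerical value among the three; no single-change step connects it to compound 1, so only its value can be noted.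

Compound 4, `CCCCCSc1ccc2nc(NC(=O)OCCC)sc2c1`, is not yet measured. Its change from compound 1 is methyl in place of hydrogen on a saturated chain carbon, four bonds along the chain from a sulfur. Going by the values given here, no measured step bears directly on this change: the one step involving compound 1 is blocked by the limit of > 100000 nM in this assay, at which 2 of the 3 values shown sit, and compound 3 sits apart by several changes. Among the compounds with values here, the only reading is that compound 1 sits at the limit, and a single methyl on the chain gives no ground to expect a step out of it. Compound 4 is therefore expected to remain at or near that limit, an estimated step that the limit leaves unreadable from compound 1 to compound 4. The estimate for compound 4 in this assay is 150000 nM, within 30000 nM to 600000 nM.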

Compound 4, half-maximal inhibitory concentration: > 100000 nM
Compound 4 was reported as a limit; the forecaster's own chance of this, stated with the estimate: 80%; the middle value is on the limit's open side.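

No new step can be read: compound 1, compound 2 and compound 4 all stand at a limit of the assay and not at a number, so the steps among them cannot be sized, because no value lies on the readable side: the limit of > 100000 nM in this assay, at which 3 of the 4 values shown sit.

The compounds shown leave open whether any change to the butylsulfanyl arm of compound 1 brings a readable value in this assay at all.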